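Lactam ring versus oxazole at the chain carbon of compound 3

This account rests on a few compounds, and the source may have more. Where it says the series, first, only, none or still open, it means among the compounds named here.

Measured compounds:
Compound 1, `CC(C)C(Cc1ncc[nH]1)c1ccc(-c2ccc3cccc(F)c3c2)[nH]c1=O`, gives 11 nM in an assay on CHO cells for displacement of a labelled ligand from prostaglandin E2 receptor EP3 subtype (Homo sapiens), read by radioligand binding; a higher number here means a weaker inhibitor, a lower number a stronger inhibitor.
Compound 2, `CC(C)C(/C=C1\CCNC1=O)c1ccc(-c2ccc3cccc(F)c3c2)[nH]c1=O`, gives 2.2 nM in this assay.
Compound 3, `CC(C)C(/C=C1/CCNC1=O)c1ccc(-c2ccc3cccc(F)c3c2)[nH]c1=O`, gives 5.3 nM in this assay.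

Compound 3 stands second highest of the three numbers: a 2.1-fold lower number from compound 1 to compound 3 (0.32 log units; beyond the scatter), and a 2.4-fold higher number from compound 2 to compound 3 (0.38 log units; beyond the scatter), the two compounds being drawn as the fact that one of compounds 2 and 3 is drawn with a defined configuration and the other without, at the place where they differ. Compound 4, `CC(C)C(c1ncco1)c1ccc(-c2ccc3cccc(F)c3c2)[nH]c1=O`, has not been measured. It differs from compound 3 in one place: a group of 5 heavy atoms (3 carbon, 1 nitrogen, 1 oxygen; one five-membered aromatic ring with 2 hetero atoms) in place of a group of 7 heavy atoms (5 carbon, 1 nitrogen, 1 oxygen; one five-membered non-aromatic ring with 1 hetero atom), on a saturated chain carbon bound to an aromatic carbon and a saturated chain carbon.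

Within the data shown here, two measured steps bear on this change, both running the opposite way. Replacing a five-membered aromatic ring with 2 hetero atoms by the lactam group gave a 5.0-fold lower number from compound 1 to compound 2 (0.70 log units; beyond the scatter) and a 2.1-fold lower number from compound 1 to compound 3 (0.32 log units; beyond the scatter). Compound 4 returns to a five-membered aromatic ring with 2 hetero atoms, now with no hydrogen-bond donor and a smaller group, so a higher number than compound 3 is expected, roughly undoing the gain seen from compound 1. The expected step is a 3.8-fold higher number from compound 3 to compound 4 (0.58 log units; beyond the scatter). Compound 4 is therefore estimated at 20 nM, with a range from 6 nM to 70 nM.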

Compound 4, inhibition constant: 24 nM
Compound 4: the middle estimate sits 1.2-fold (0.08 log units) below what was measured; the range from low to high includes it.
By their numbers in this assay, from the lowest: compound 2; then compound 3; then compound 1; then compound 4.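

Putting the 1,3-oxazol-2-yl group on the saturated chain carbon costs what the lactam groups had gained, with a 4.5-fold higher number from compound 3 to compound 4 (0.66 log units; beyond the scatter) and an 11-fold higher number from compound 2 to compound 4 (1.04 log units; beyond the scatter) in this assay. The oxazole also falls short of the (1H-imidazol-2-yl)methyl group, with a 2.2-fold higher number from compound 1 to compound 4 (0.34 log units; beyond the scatter), so among these four compounds both lactam forms give lower numbers than either aromatic ring, and the oxazole gives the highest number of all. Nothing measured here accounts for these steps.

From the compounds shown here alone, the step from the (1H-imidazol-2-yl)methyl group to the oxazole changes the ring and the chain together, so the share of each stays unknown. Going by these compounds, a 1,3-oxazol-2-ylmethyl group would separate the two, and how an amine or a carboxylic acid on this carbon would fare remains open.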